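Methylating a Ring Nitrogen in a Macrocyclic Series

The compounds below may be only part of what the source reports. "The series", "measured", "known", "first", "only" and "open" are said of these compounds alone.

Measured so far:
compound 1, `COc1ccc2c(O[C@@H]3C[C@H]4C(=O)N[C@]5(C(=O)NS(=O)(=O)C6CC6)C[C@H]5/C=C\CCCCCNC(=O)N4C3)cc(-c3nc(C(C)C)cs3)nc2c1`, 5140 ng.h/mL
compound 2, `COc1ccc2c(O[C@@H]3C[C@H]4C(=O)N[C@]5(C(=O)NS(=O)(=O)C6CC6)C[C@H]5/C=C\CCCCNC(=O)N4C3)cc(-c3nc(C(C)C)cs3)nc2c1`, 137 ng.h/mL

Two macrocyclic compounds have been measured in an ADME assay on the whole organism (plasma, strain Sprague-Dawley) for pharmacokinetics, with Rattus norvegicus as the target, at a dose of 10 mg/kg by the oral route; on this read-out higher numbers stand for higher exposure at the dose given and lower numbers for lower exposure. Compound 1 gives 5140 ng.h/mL. Compound 2 gives 137 ng.h/mL, the lower of the two numbers, and the gap to compound 1 is beyond the usual scatter of repeated measurements. Among the measured compounds shown here, these two compounds differ in more than one place, so the numbers alone say only that compound 1 gives far higher exposure.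

Compound 3 is `COc1ccc2c(O[C@@H]3C[C@H]4C(=O)N[C@]5(C(=O)NS(=O)(=O)C6CC6)C[C@H]5/C=C\CCCCN(C)C(=O)N4C3)cc(-c3nc(C(C)C)cs3)nc2c1`. Compared with compound 2, the change is methyl in place of hydrogen on an amide-type nitrogen in a ring. For the measured compounds named here, no measured pair in this small set carries the same change, so there is nothing to lean on except the values of compounds 1 and 2. On that basis, a modest rise in this assay seems more likely than a fall, though a result within the scatter of compound 2 cannot be ruled out.

Compound 3 is therefore expected to give 500 ng.h/mL, with a range from 100 ng.h/mL to 2500 ng.h/mL, which means an estimated step of a 3.6-fold higher number from compound 2 to compound 3 (0.56 log units; beyond the scatter).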

Compound 3, area under the concentration-time curve: 2300 ng.h/mL
Compound 3: middle estimate off by 4.6-fold (0.66 log units), on the low side, within the range that was stated.
By their numbers in this assay, from the lowest: compound 2; then compound 3; then compound 1.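

In this assay, a methyl in place of hydrogen on this amide-type nitrogen in the 14-membered ring brings a 17-fold higher number from compound 2 to compound 3 (1.23 log units; beyond the scatter) and so shows that exposure responds strongly to this one position. Among the compounds shown here, the earlier compounds differed in more than one place and could not tie a change in exposure to any single site, whereas here the only change is one added carbon. No measurement shown explains the rise in exposure.

Still open, going by these compounds, is whether a larger group on this nitrogen, such as ethyl or cyclopropyl, would act as methyl does, and whether methyl would give a similar step on the core of compound 1. Exposure alone also does not separate how much of a compound is absorbed from how quickly it is cleared.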